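Cyclohexyloxy replacing the aryl at the pyrazole position

The compounds below may be only part of what the source reports. "The series", "measured", "known", "first", "only" and "open" are said of these compounds alone.

Three amides sharing one core have numbers in a functional assay on HEK293 cells for negative allosteric modulation of metabotropic glutamate receptor 5 (Homo sapiens), read by FLIPR and calcium flux; a higher number here means a weaker inhibitor, a lower number a stronger inhibitor. Compound 1 `Cc1cccc(NC(=O)c2nn(C)c(-c3ccccc3)c2C)n1` gives 4.4 nM. Compound 2 `Cc1cccc(NC(=O)c2nn(C)c(-c3ccc(F)cc3F)c2C)n1` gives 3.7 nM, the lowest of the three numbers, though the step of a 1.2-fold lower number from compound 1 to compound 2 (0.08 log units; within the scatter) lies within the scatter, so compound 1 and compound 2 cannot be ordered. Compound 3 `Cc1cccc(NC(=O)c2nn(C)c(-c3ccc(C(F)(F)F)cc3)c2C)n1` gives 38 nM; the step of an 8.6-fold higher number from compound 1 to compound 3 (0.94 log units; beyond the scatter) is beyond the scatter and modest in size.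

Compound 4 `Cc1cccc(NC(=O)c2nn(C)c(OC3CCCCC3)c2C)n1` is not yet measured. It differs from compound 2 as follows: cyclohexyloxy in place of 2,4-difluorophenyl on an aromatic carbon. Neither measured step covers this change: both keep a phenyl-type ring at the place in question and vary only its fluorine or trifluoromethyl substitution. The step from compound 1 to compound 3 shows that alteration at this place can move the number by a modest amount, and the exchange of a whole aromatic ring for cyclohexyloxy is a larger departure than any measured here. A weakening step is therefore expected in this assay, a 6.8-fold higher number from compound 2 to compound 4 (0.83 log units; beyond the scatter), with wide uncertainty. For compound 4 the estimate is 25 nM, with a range from 5 nM to 150 nM.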

Compound 4, half-maximal inhibitory concentration: 92 nM
Compound 4: the middle estimate sits 3.7-fold (0.57 log units) below what was measured; measured number inside the range.
By their numbers in this assay, from the lowest: compounds 2 and 1 (each within the scatter of the next); then compound 3; then compound 4.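

Cyclohexyloxy is the first change at this place that removes the aromatic ring rather than altering its substituents, and in this assay it gives a 25-fold higher number from compound 2 to compound 4 (1.40 log units; beyond the scatter) and a 21-fold higher number from compound 1 to compound 4 (1.32 log units; beyond the scatter). Both steps are large, whereas the trifluoromethyl change, an 8.6-fold higher number from compound 1 to compound 3 (0.94 log units; beyond the scatter), is modest, so among these compounds the exchange of the whole aryl group for cyclohexyloxy moves the number further than the substitution on the phenyl ring does. Nothing available here bears on what lies behind these steps.

The exchange alters two things at once, the aromatic ring and the oxygen link, and the compounds shown do not separate them; phenoxy and a directly attached cyclohexyl would do so. Smaller or open-chain ethers, such as methoxy or isopropoxy, also remain open at this place.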